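The compounds below may be only part of what the source reports. "The series", "measured", "known", "first", "only" and "open" are said of these compounds alone.

Working notes. The series shares one core and differs only in the group on an aromatic carbon. Compound 1 `O=C(NN1CCOCC1)C1=NN(c2ccc(Cl)cc2Cl)C(c2ccccc2)C1` is the unsubstituted parent; in a functional assay on the whole organism (strain Zucker) for inhibition, with Rattus norvegicus as the target, with a stated time of 4 h, at a dose of 10 mg/kg by the oral route (a higher number here means more inhibition at the dose given (going by the name of the read-out), a lower number less inhibition), compound 1 gives 31.9%. Compound 2 `CCCCCc1ccc(C2CC(C(=O)NN3CCOCC3)=NN2c2ccc(Cl)cc2Cl)cc1` carries pentyl there, and in this assay compound 2 gives 13.1%. Compound 3 `CCCCOc1ccc(C2CC(C(=O)NN3CCOCC3)=NN2c2ccc(Cl)cc2Cl)cc1` carries butoxy, and in this assay compound 3 gives 18.1%. Compound 3 thus stands second of the three: within the scatter of compound 2, while a number 13.8 percentage points lower from compound 1 to compound 3 (beyond the scatter) lies beyond it. Compound 4 `COc1ccc(C2CC(C(=O)NN3CCOCC3)=NN2c2ccc(Cl)cc2Cl)cc1` differs from compound 3 by hydrogen in place of propyl on a saturated chain carbon bound to an oxygen on an aromatic ring. The bearing steps are a number 18.8 percentage points lower from compound 1 to compound 2 (beyond the scatter) and a number 13.8 percentage points lower from compound 1 to compound 3 (beyond the scatter), both losses on adding a chain, whereas a number 5 percentage points higher from compound 2 to compound 3 (within the scatter) separates the two chains little. Shortening the chain toward the parent should partly undo that loss. The expected step is a number 6.9 percentage points higher from compound 3 to compound 4 (within the scatter). Compound 4 is estimated at 25%, ranging from 12% to 38%.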

Compound 4, a percentage reported as inhibition, in the whole organism at one dose (the size of the read-out at that dose, not a potency): 9.4%
Estimate against measurement, compound 4: 15.6 percentage points above; measured number below the stated range.
By their numbers in this assay, from the lowest: compounds 4, 2 and 3 (each within the scatter of the next); then compound 1.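

Going from butoxy to methoxy does not move the number back toward the parent in this assay: the step is a number 8.7 percentage points lower from compound 3 to compound 4 (within the scatter) and the comparison with pentyl gives a number 3.7 percentage points lower from compound 2 to compound 4 (within the scatter), so these three chains are not separated. The short methoxy group still carries the loss, with a number 22.5 percentage points lower from compound 1 to compound 4 (beyond the scatter), so among these compounds the drop goes with any of the three groups on the aromatic carbon, whatever its chain length. Nothing at hand explains this drop. Open, on these data alone, is whether a hydroxyl, an amine or a chlorine on that aromatic carbon would also fall below compound 1.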